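From phenyl to (furan-2-yl)methyl at the assay limit

This account rests on a few compounds, and the source may have more. Where it says the series, first, only, none or still open, it means among the compounds named here.

In a functional assay on Jurkat cells (Homo sapiens) for inhibition, read by CCK-8 assay, with a stated time of 48 h (a higher number here means a weaker inhibitor of growth, a lower number a stronger inhibitor of growth), compound 1 `Cc1ccccc1Nc1nc(NC2CCCCC2)ncc1Cl` gives > 100000 nM as a limit, not a number. Compound 2 `Cc1ccccc1Nc1nc(Nc2ccccc2)ncc1Cl` gives > 100000 nM and this too is only a limit. Compound 3 `Cc1ccc(Nc2ncc(Cl)c(Nc3ccccc3C)n2)cc1` gives > 100000 nM as a limit as well. All three therefore share one ceiling (the limit of > 100000 nM in this assay, at which 3 of the 3 values shown sit) and compound 2 has no exact position.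

Compound 4 `Cc1ccccc1Nc1nc(NCc2ccco2)ncc1Cl` differs from compound 2 in one place: (furan-2-yl)methyl in place of phenyl on a nitrogen on an aromatic ring on that same nitrogen.

Going by the values given here, three measured steps bear on this, and none has a readable size: a step that the two limits leave unreadable from compound 1 to compound 2 then a step that the two limits leave unreadable from compound 1 to compound 3 and a step that the two limits leave unreadable from compound 2 to compound 3 as well. They show no direction, so compound 4 is expected to stay close to the ceiling.

The estimated step is an at least 1.6-fold lower number from compound 2 to compound 4 (0.22 log units; that floor lies within the scatter) with no firm direction. Compound 4 is expected at 60000 nM with an estimated range from 10000 nM to 150000 nM in this assay's terms.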

Compound 4, concentration for 50% growth inhibition: > 100000 nM
Compound 4: only a limit was reported (the forecaster's own chance of this, stated with the estimate: 60%); middle value at least 1.6-fold (0.22 log units) from the limit.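

The steps from compound 1, compound 2 and compound 3 to compound 4 cannot be read, as all four sit at one ceiling: the limit of > 100000 nM in this assay, at which 4 of the 4 values shown sit.

The compounds shown leave open whether any of these groups on that nitrogen changes growth inhibition in this assay at all, with no exact number among them.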